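Isobutyl in place of isopropyl on compound 3

The compounds below may be only part of what the source reports. "The series", "measured", "known", "first", "only" and "open" are said of these compounds alone.

Compound 1 `CC(C)[C@@H](N)C(=O)OC[C@H]1O[C@@H](n2cnc3c(N)ncnc32)[C@@H](O)[C@@H]1O`: > 10000 ug/mL
Compound 2 `Nc1ncnc2c1ncn2[C@@H]1O[C@H](COC(=O)C[C@@H](N)C(=O)O)[C@@H](O)[C@@H]1O`: > 10000 ug/mL
Compound 3 `CC(C)[C@H](N)C(=O)OC[C@H]1O[C@@H](n2cnc3c(N)ncnc32)[C@@H](O)[C@@H]1O`: > 10000 ug/mL

In a physicochemical assay for solubility (on this read-out lower numbers stand for lower solubility and higher numbers for higher solubility), compound 3 gives > 10000 ug/mL, which is a limit and not a number. Compound 1 gives > 10000 ug/mL, also a limit. Compound 2 gives > 10000 ug/mL, again a limit. What the set offers is therefore (the limit of > 10000 ug/mL in this assay, at which 3 of the 3 values shown sit).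

Compound 4 `CC(C)C[C@H](N)C(=O)OC[C@H]1O[C@@H](n2cnc3c(N)ncnc32)[C@@H](O)[C@@H]1O` has not yet been measured. It carries one change, (isobutyl in place of isopropyl on a saturated chain carbon bound to an amine nitrogen and a carbonyl carbon), so that isobutyl replaces isopropyl on a saturated chain carbon bound to an amine nitrogen and a carbonyl carbon.

The closest measured change at this group is a step that the two limits leave unreadable from compound 2 to compound 3. Also relevant is the fact that compounds 1 and 3 differ only in the configuration as drawn, which gives a step that the two limits leave unreadable from compound 1 to compound 3. The remaining measured step is a step that the two limits leave unreadable from compound 1 to compound 2. None of these has a size that can be carried over, so no direction is expected beyond the scatter. The estimated change is a step that the limit leaves unreadable from compound 3 to compound 4. Compound 4 is expected at about 12000 ug/mL, with an estimated range of 4000 ug/mL to 40000 ug/mL, and it will probably be reported only as a limit.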

Compound 4, solubility: > 10000 ug/mL
Compound 4: no number, only a limit; the forecaster's own chance of this, stated with the estimate: 80%; the middle value lies beyond the limit too.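

In this assay compound 4 gives > 10000 ug/mL as a limit, not a number. Going by these compounds alone, no step from compound 1, compound 2 or compound 3 to compound 4 can be read. The compounds shown leave open how their solubilities compare beyond this shared limit.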